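This account rests on a few compounds, and the source may have more. Where it says the series, first, only, none or still open, it means among the compounds named here.

This account concerns a small set of compounds built on a shared core and examined in a functional assay on HeLa cells (Homo sapiens) for inhibition, read by MTT assay, with a stated time of 48 h; a lower number here means a stronger inhibitor, a higher number a weaker inhibitor. For the measured compounds named here, compound 2 `CS(=O)(=O)Nc1ccc(-n2cc(-c3ccccc3)nn2)cc1Oc1ccccc1` is the only member for which a number is available: in this assay compound 2 gives 21900 nM, which places it among weak inhibitors. Compound 1 `CS(=O)(=O)Nc1ccc(-n2cc(COc3ccc([N+](=O)[O-])cc3)nn2)cc1Oc1ccccc1` belongs to the same set, but in this assay compound 1 gives "not determined" (no result reported). Compound 3 `Cc1ccc(-c2cn(-c3ccc(NS(C)(=O)=O)c(Oc4ccccc4)c3)nn2)cc1` is in the same position: in this assay compound 3 gives "not determined" (no result reported). So compound 2 stands alone and nothing can be said about how it compares with them.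

Compound 4 `CS(=O)(=O)Nc1ccc(-n2cc(COc3ccc(Cl)cc3)nn2)cc1Oc1ccccc1` has not yet been measured. It differs from compound 2 in one place: (4-chlorophenoxy)methyl in place of phenyl on an aromatic carbon. Going by the values given here, no step between two measured compounds is available, so the data give no direct guide to how much such a replacement moves the number.

Given that compound 2 gives 21900 nM, the expectation is that compound 4 stays in the same weak region. The step of a 1.5-fold lower number from compound 2 to compound 4 (0.16 log units; within the scatter) is expected to be small, possibly a modest gain, possibly nothing beyond the usual scatter. The estimate for compound 4 in this assay is therefore 15000 nM, with a range from 4000 nM to 60000 nM.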

Compound 4, half-maximal inhibitory concentration: 7800 nM
Beside the measured number, compound 4's estimate is 1.9-fold (0.28 log units) above it; the range from low to high includes it.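

For the compounds shown here, replacing phenyl with (4-chlorophenoxy)methyl gives the first reading of this position, on an aromatic carbon of the five-membered aromatic ring with 3 nitrogen: in this assay the change produces a 2.8-fold lower number from compound 2 to compound 4 (0.45 log units; beyond the scatter), a modest step. The position therefore tolerates this larger group, which also brings a hydrogen-bond acceptor and places its aromatic ring further out, with a small gain rather than a loss, although compound 4 at 7800 nM is still far from a strong inhibitor. No measurement at hand bears on the cause of this step.

The steps involving compound 1 and compound 3 cannot be read, as neither has a number, so the compounds shown cannot separate the contribution of the chlorine from that of the oxygen-bearing link to the ring. They also leave open how this assay would respond to an amine, a carboxylic acid or a longer chain at this position, and whether the modest gain seen here would extend to any group other than (4-chlorophenoxy)methyl.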